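The compounds below may be only part of what the source reports. "The series", "measured", "known", "first", "only" and "open" are said of these compounds alone.

Measured in a functional assay on PC-3 cells (Homo sapiens) for cytotoxicity, read by MTT assay, with a stated time of 24 h (on this read-out lower numbers stand for stronger inhibition and higher numbers for weaker inhibition), so far:
- Compound 1 `O=C1/C(=C/c2ccccc2F)CN(Cc2cn(Cc3ccccc3F)nn2)C/C1=C\c1ccccc1F` gives 19700 nM
- Compound 2 `COc1ccc(/C=C2\CN(C(=S)SCc3cn(Cc4ccc(F)cc4)nn3)C/C(=C\c3ccc(OC)cc3)C2=O)cc1` gives 45600 nM

Compound 1 has the lower of the two numbers (19700 nM), and compound 2 gives 45600 nM. The gap between the two lies beyond the scatter. Compound 3 `O=C1/C(=C/c2ccccc2F)CN(Cc2cn(Cc3cccc(Cl)c3)nn2)C/C1=C\c1ccccc1F` keeps the core of compound 1 and changes one group (3-chlorophenyl in place of 2-fluorophenyl on a saturated chain carbon bound to an aromatic nitrogen): 3-chlorophenyl in place of 2-fluorophenyl on a saturated chain carbon bound to an aromatic nitrogen. Among the measured compounds shown here, no measured pair shows this change, so in this assay only a small step of no firm direction is expected, inside the usual scatter (a 1.1-fold lower number from compound 1 to compound 3 (0.04 log units; within the scatter)). Compound 3 is expected at 18000 nM (estimated range 8000 nM to 40000 nM).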

Compound 3, half-maximal inhibitory concentration: 6800 nM
Beside the measured number, compound 3's estimate is 2.6-fold (0.42 log units) above it; measured number outside the range, below it.
By their numbers in this assay, from the lowest: compound 3; then compound 1; then compound 2.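

This step shows that the group on the saturated chain carbon bound to an aromatic nitrogen can shift the result: in this assay the change from 2-fluorobenzyl to 3-chlorobenzyl gives a 2.9-fold lower number from compound 1 to compound 3 (0.46 log units; beyond the scatter) with the rest of the molecule unchanged. Compounds 1 and 2 differ in more than one place, so they could not isolate this position. No measurement here bears on why the number falls.

The change swaps the halogen and shifts its place on the ring together, so 2-chlorobenzyl and 3-fluorobenzyl would be needed to separate the two. As far as these compounds go, how plain benzyl or 3-methoxybenzyl would compare also remains open.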